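Swapping Ethyl for Vinyl on the Amine Nitrogen

The source may report more compounds than this note shows. Statements on the series, on what has been measured and on what is new or still open speak of the compounds shown alone.

Measured so far:
Compound 1 `CCN(Cc1c(C(F)(F)F)nc2n(-c3c(C)cc(C)cc3C)c(Cl)cn12)CC1CC1` gives 9 nM in an assay on cells for displacement of a labelled ligand from corticotropin-releasing factor receptor 1 (Homo sapiens), with a stated time of 100 min; on this read-out higher numbers stand for weaker inhibition and lower numbers for stronger inhibition.
Compound 2 `Cc1cc(C)c(-n2c(Cl)cn3c(CN(CCC(F)(F)F)CC4CC4)c(C(F)(F)F)nc23)c(C)c1` gives 16 nM in this assay.
Compound 3 `C=CCN(CCC)Cc1c(C(F)(F)F)nc2n(-c3c(C)cc(C)cc3C)c(Cl)cn12` gives 4.5 nM in this assay.

All three share one core and differ only in the two groups carried by the amine nitrogen. Compound 3 gives the lowest number of the three, but the gap to compound 1 is small, a 2.0-fold lower number from compound 1 to compound 3 (0.30 log units; within the scatter), so those two are not told apart; only compound 2 stands clearly apart, a 3.6-fold lower number from compound 2 to compound 3 (0.55 log units; beyond the scatter).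

Compound 4 `C=CCN(CC=C)Cc1c(C(F)(F)F)nc2n(-c3c(C)cc(C)cc3C)c(Cl)cn12` has not yet been measured. It differs from compound 3 by vinyl in place of ethyl on a saturated chain carbon bound to an amine nitrogen. Within the data shown here, the steps that bear on this are the two changes of amine substituents already seen, one within the scatter and one modest, so another small change at the same place is expected to move the number little, if at all, beyond the scatter.

Compound 4 is therefore estimated to give about 5 nM in this assay, between 2 nM and 13 nM. The step this estimate means, a 1.1-fold higher number from compound 3 to compound 4 (0.05 log units; within the scatter), is expected to stay within the scatter.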

Compound 4, inhibition constant: 13 nM
For compound 4 the middle estimate is 2.6-fold (0.41 log units) below the measured one, and the stated range covers the measured number.
By their numbers in this assay, from the lowest: compounds 3, 1, 4 and 2 (each within the scatter of the next, the first and the last beyond it).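

In this assay, replacing the propyl group of compound 3 with allyl gives a clear step (a 2.9-fold higher number from compound 3 to compound 4 (0.46 log units; beyond the scatter)). Among these compounds, the two groups have the same heavy-atom count, and the one added feature is a double bond outside aromatic rings, so this small edit on the amine nitrogen can move the number beyond the scatter, a finer change at this place than any step among the earlier compounds. Even so, the diallylamino group of compound 4 cannot be told apart from the amine groups of the other two compounds (a 1.2-fold lower number from compound 2 to compound 4 (0.09 log units; within the scatter); a 1.4-fold higher number from compound 1 to compound 4 (0.16 log units; within the scatter)).

No measurement shown explains the step from propyl to allyl. Also open, as far as these compounds go, is how the number would respond to a dipropylamino group, which carries two saturated propyl chains on the nitrogen, or to a longer chain such as butyl.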